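Chalcones on a shared core: dichlorophenyl replaces furan

A few compounds are considered here, and "the series" means these few. Any claim that something is new, unique, unknown or untested is made for them only; others in the source may bear on it.

Compound 1 `COc1cccc(/C=C/C(=O)c2ccc(OC)c3c2OC(C)(C)C=C3)c1`: > 10000 nM, a limit
Compound 2 `COc1ccc(C(=O)/C=C/c2ccco2)c2c1C=CC(C)(C)O2`: > 10000 nM, a limit

In a functional assay on HCT-116 cells (Homo sapiens) for antiproliferative activity, read by MTT assay, with a stated time of 24 h (on this read-out higher numbers stand for weaker inhibition and lower numbers for stronger inhibition), compound 1 gives only a limit, > 10000 nM. In this assay compound 2 also gives only a limit, > 10000 nM. For the measured compounds named here, compound 2 therefore stands at the limit of > 10000 nM in this assay, at which 2 of the 2 values shown sit, where every value shown sits, and the one step between measured compounds, a step that the two limits leave unreadable from compound 1 to compound 2, cannot be read. Compound 3 `COc1ccc(C(=O)/C=C/c2ccc(Cl)c(Cl)c2)c2c1C=CC(C)(C)O2` differs from compound 2 by 3,4-dichlorophenyl in place of furan-2-yl on a double-bonded chain carbon bound to a double-bonded chain carbon. Going by the values given here, no readable measured step bears on this change, since a step that the two limits leave unreadable from compound 1 to compound 2 is hidden by the two limits, so no step in this assay beyond the scatter can be foreseen in either direction, and a further limit is the likeliest outcome. Compound 3 is expected to give about 10000 nM in this assay, between 2500 nM and 40000 nM. The expected step is a number no higher from compound 2 to compound 3 (the limit leaves the size open), estimated as essentially flat.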

Compound 3, half-maximal inhibitory concentration: 9440 nM
Beside the measured number, compound 3's estimate is 1.1-fold (0.03 log units) above it, within the range that was stated.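

At this position on the shared core, 3,4-dichlorophenyl is the first of the groups shown to give a number rather than a limit in this assay. In place of furan-2-yl it gives an at least 1.0-fold lower number from compound 2 to compound 3 (0.02 log units; that floor lies within the scatter), and in place of 3-methoxyphenyl it gives an at least 1.0-fold lower number from compound 1 to compound 3 (0.02 log units; that floor lies within the scatter). Each step is known only as a floor because the other compound in each pair sits at a limit: the limit of > 10000 nM in this assay, at which 2 of the 3 values shown sit.

As far as these compounds go, how large either step truly is remains open, and the step between the two earlier compounds still cannot be read. Also open, from the compounds shown here alone, is whether a single chlorine on the phenyl ring, or an amine or a carboxylic acid on the same chain carbon, would give a number in this assay.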